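A few compounds are considered here, and "the series" means these few. Any claim that something is new, unique, unknown or untested is made for them only; others in the source may bear on it.

Measured so far in an ADME assay on PANC-1 cells (Homo sapiens) for inhibition, read by MTT assay; on this read-out lower numbers stand for stronger inhibition of growth and higher numbers for weaker inhibition of growth:

compound 1, `Cc1nc(C)c(-c2nn(-c3ccc(F)cc3)cc2/C=C/C(=O)c2cc(Br)ccc2O)s1`: > 250 ug/mL
compound 2, `Cc1nc(C)c(-c2nn(-c3ccc(F)cc3)cc2/C=C/C(=O)c2cc(Cl)ccc2O)s1`: > 250 ug/mL
compound 3, `Cc1ccc(O)c(C(=O)/C=C/c2cn(-c3ccc(F)cc3)nc2-c2sc(C)nc2C)c1`: 52.4 ug/mL

Compound 1 gives only a limit of this assay, > 250 ug/mL. Compound 2 likewise gives only a limit, > 250 ug/mL. Among the measured compounds shown here, compound 3 is the one member of the series with a number, 52.4 ug/mL, and so stands apart from the other two, which both sit at the limit of > 250 ug/mL in this assay, at which 2 of the 3 values shown sit. The step that the two limits leave unreadable from compound 1 to compound 2 cannot be read. The two readable steps are an at least 4.7-fold lower number from compound 1 to compound 3 (0.67 log units; beyond the scatter) and an at least 4.7-fold lower number from compound 2 to compound 3 (0.67 log units; beyond the scatter): methyl in place of either halogen on the aromatic carbon brings the number down from the limit by an at least modest margin.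

Compound 4, `Cc1nc(C)c(-c2nn(-c3ccc(F)cc3)cc2/C=C/C(=O)c2c(O)cc(C)c(Cl)c2C)s1`, is still to be measured. It differs from compound 3 by 3-chloro-6-hydroxy-2,4-dimethylphenyl in place of 2-hydroxy-5-methylphenyl on a carbonyl carbon. For the measured compounds named here, the entering group carries a chlorine along with two methyls, so the only measured steps that bear on it are the halogen-to-methyl exchanges above, read in reverse: reintroducing chlorine points toward a higher number, while the added methyls leave the outcome uncertain. The expected step is a 2.3-fold higher number from compound 3 to compound 4 (0.36 log units; beyond the scatter), toward weaker inhibition, with a fair chance that only a limit is returned. Compound 4 is expected to give about 120 ug/mL, within a range of 40 ug/mL to 250 ug/mL.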

Compound 4, concentration for 50% growth inhibition: 35.2 ug/mL
Estimate against measurement, compound 4: 3.4-fold (0.53 log units) above; measured number outside the range, below it.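

In this assay, the change on the carbonyl carbon gives a 1.5-fold lower number from compound 3 to compound 4 (0.17 log units; within the scatter), a step within the scatter, so 3-chloro-6-hydroxy-2,4-dimethylphenyl and 2-hydroxy-5-methylphenyl cannot be told apart here, and a chlorine on this phenyl ring does not by itself go with a limit. Against the two halogen-bearing groups that give only limits, the same position shows an at least 7.1-fold lower number from compound 2 to compound 4 (0.85 log units; beyond the scatter) and an at least 7.1-fold lower number from compound 1 to compound 4 (0.85 log units; beyond the scatter), both beyond the scatter, which separates the chlorine-bearing group of compound 4 from 5-chloro-2-hydroxyphenyl and 5-bromo-2-hydroxyphenyl in a way the earlier compounds could not show. Among the compounds shown here, compound 1 and compound 2 remain the only members that give a limit and not a number: the limit of > 250 ug/mL in this assay, at which 2 of the 4 values shown sit.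

The compounds shown do not separate the contribution of the chlorine from that of the two methyls in compound 4, since all of them enter together in one step. Going by these compounds, whether an amine or a carboxylic acid on this phenyl ring, or a methoxy group in place of the hydroxy, would still give a readable number stays open.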